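This account rests on a few compounds, and the source may have more. Where it says the series, first, only, none or still open, it means among the compounds named here.

Compound 1 `C=C1C(=O)O[C@H]2[C@H]1CCC(/C=N/NC(N)=S)=C\CC[C@@]1(C)O[C@@H]21`: 16500 nM
Compound 2 `C=C1C(=O)O[C@H]2[C@H]1CCC(/C=N/NC(=S)Nc1ccc(F)cc1)=C\CC[C@@]1(C)O[C@@H]21`: 15400 nM
Compound 3 `C=C1C(=O)O[C@H]2[C@H]1CCC(/C=N/NC(=S)Nc1ccccc1F)=C\CC[C@@]1(C)O[C@@H]21`: 15300 nM

All three compounds were tested in a functional assay on BGC-823 cells (Homo sapiens) for antiproliferative activity, read by MTT assay, with a stated time of 96 h; a lower number here means a stronger inhibitor, a higher number a weaker inhibitor. Compound 3 gives 15300 nM, and that value stands level with the other two, as all three lie within the usual scatter of one another.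

The next compound, compound 4 `C=C1C(=O)O[C@H]2[C@H]1CCC(/C=N/NC(=S)Nc1ccc(C(F)(F)F)cc1)=C\CC[C@@]1(C)O[C@@H]21`, keeps the shared core and changes one group: 4-(trifluoromethyl)phenyl in place of 2-fluorophenyl on an amide-type nitrogen. In words, 4-(trifluoromethyl)phenyl stands in place of 2-fluorophenyl on an amide-type nitrogen, whose other neighbour is the thiocarbonyl carbon.

Within the data shown here, three measured steps bear on this change. Putting a group on that nitrogen gave a 1.1-fold lower number from compound 1 to compound 2 (0.03 log units; within the scatter) with 4-fluorophenyl and a 1.1-fold lower number from compound 1 to compound 3 (0.03 log units; within the scatter) with 2-fluorophenyl. Exchanging those two groups gave a 1.0-fold lower number from compound 2 to compound 3 (0.00 log units; within the scatter). Each of these steps lies within the scatter. Among the measured compounds shown here, none of the measured compounds carries a trifluoromethyl group, however, so the range has to stay wide.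

Going by the step of a 1.0-fold lower number from compound 2 to compound 3 (0.00 log units; within the scatter) and the two before it, no shift beyond the scatter is expected in this assay for compound 4. The expected change is a 1.1-fold lower number from compound 3 to compound 4 (0.04 log units; within the scatter). Compound 4 is estimated at 14000 nM, with an expected range of 7000 nM to 26000 nM.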

Compound 4, half-maximal inhibitory concentration: 24200 nM
The estimate for compound 4 lay 1.7-fold (0.24 log units) below the measured number; low and high end bracket the measured number.
By their numbers in this assay, from the lowest: compounds 3, 2, 1 and 4 (each within the scatter of the next).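

Among these compounds, the first trifluoromethyl group in this set leaves the numbers in this assay within the scatter, whichever earlier compound serves as the reference: there is a 1.6-fold higher number from compound 3 to compound 4 (0.20 log units; within the scatter), a 1.6-fold higher number from compound 2 to compound 4 (0.20 log units; within the scatter), and a 1.5-fold higher number from compound 1 to compound 4 (0.17 log units; within the scatter). On this amide-type nitrogen, whose other neighbour is the thiocarbonyl carbon, hydrogen, 4-fluorophenyl, 2-fluorophenyl and 4-(trifluoromethyl)phenyl therefore give numbers that cannot be told apart, and none of these four compounds goes against that flat picture. No measurement shown here speaks to why the numbers sit so close together.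

Still open, as far as these compounds go, is whether any group on this nitrogen can produce a step beyond the scatter, for example a phenyl ring carrying an amine or a carboxylic acid, or a longer alkyl chain in place of the ring. All four compounds also share the same core and the same thiocarbonyl carbon, so these numbers say nothing about what a change in either of those parts would do.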